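The source may hold more compounds than are shown below. What is called first, only, known or untested is meant among the compounds shown, and "the series" means these compounds.

Measured compounds:
compound 1 `COc1cc(C(=O)O)ccc1OCCCCOc1ccc(C(=O)CC(C)C)c(O)c1C` — 614 nM
compound 2 `Cc1c(OCCCCOc2ccc(C(=O)O)cc2)ccc(C(=O)CC(C)C)c1C` — "not determined" (no result reported)

In an assay on HEK293 cells for positive allosteric modulation of metabotropic glutamate receptor 3 (Rattus norvegicus), read by thallium flux, with a stated time of 2.5 min (on this read-out higher numbers stand for an effect only at larger amounts of compound and lower numbers for an effect already at smaller amounts), compound 1 gives 614 nM. In this assay compound 2 gives "not determined" (no result reported), so there is no anchor for it. Compound 3 `Cc1c(OCCCCOc2ccc(C(=O)O)cc2)ccc(C(=O)CC(C)C)c1O` differs from compound 2 by hydroxy in place of methyl on an aromatic carbon. For the measured compounds named here, with no value for compound 2 and no step between measured compounds, neither size nor direction of the change in this assay can be drawn from the data; compound 1, which also carries a hydroxy on that aromatic carbon, is the only reference. Compound 3 is estimated at 900 nM, expected range 250 nM to 4000 nM.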

Compound 3, half-maximal effective concentration: 2720 nM
Estimate against measurement, compound 3: 3.0-fold (0.48 log units) below; the measured number falls inside the stated range.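

In this assay the series now has its first readable step, a 4.4-fold higher number from compound 1 to compound 3 (0.65 log units; beyond the scatter), with the hydroxy and the methyl of the shared core unchanged, so the number here does respond to the methoxy of compound 1. The change from methyl to hydroxy itself cannot be read: compound 2 has no number. Nothing on hand gives a reason for the step. Open, from the compounds shown here alone, is whether ethoxy or fluorine in place of that methoxy keeps the lower number, and what an amine in place of the hydroxy does.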